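A few compounds are considered here, and "the series" means these few. Any claim that something is new, unique, unknown or untested is made for them only; others in the source may bear on it.

Compound 1 `CC(=O)c1cc(-c2ccccc2)cc2cc(-c3ccc(F)cc3)[nH]c12`: 68.3%
Compound 2 `CC(=O)c1cc(/C=C/c2ccc(F)cc2)cc2cc(-c3ccccc3)[nH]c12`: 23.9%
Compound 3 `CC(=O)c1cc(/C=C/c2ccccc2)cc2cc(-c3ccc(F)cc3)[nH]c12`: 24.3%

In a functional assay on HeLa cells (Homo sapiens) for cytotoxicity, read by MTT assay, with a stated time of 2 days, tested at 100 uM (a higher number here means a weaker effect of the compound at the concentration tested, a lower number a stronger effect), compound 3 gives 24.3%, the second highest of the three numbers. Compound 2 gives 23.9%, within the scatter of that, and compound 1 gives 68.3%. Among the measured compounds shown here, the single measured step, a number 44 percentage points lower from compound 1 to compound 3 (beyond the scatter), concerns a different change. Compound 4 `CC(=O)c1cc(/C=C/c2ccc(F)cc2)cc2cc(-c3ccc(F)cc3)[nH]c12` differs from compound 3 by fluoro in place of hydrogen on an aromatic carbon. For the measured compounds named here, no measured step bears on a fluoro in place of hydrogen; compound 2 and compound 3, which carry their fluoro on different rings, give numbers within the scatter of each other. The step of a number 0.3 percentage points lower from compound 3 to compound 4 (within the scatter) is therefore expected to stay within the scatter. Compound 4 is estimated at 24%, with a range from 10% to 40%.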

Compound 4, a percentage reported as activity, at one concentration (the size of the read-out at that concentration, not a potency): 20.3%
For compound 4 the middle estimate is 3.7 percentage points above the measured one; measured number inside the range.
By their numbers in this assay, from the lowest: compounds 4, 2 and 3 (each within the scatter of the next); then compound 1.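

In this assay fluoro in place of hydrogen, read at both rings, gives a number 4 percentage points lower from compound 3 to compound 4 (within the scatter) when 2-phenylethenyl becomes 2-(4-fluorophenyl)ethenyl and a number 3.6 percentage points lower from compound 2 to compound 4 (within the scatter) when phenyl becomes 4-fluorophenyl . With both fluoro groups present, the replacement of phenyl by 2-(4-fluorophenyl)ethenyl still gives a number 48 percentage points lower from compound 1 to compound 4 (beyond the scatter). No measurement shown here explains these results. As far as these compounds go, whether an amine or a carboxylic acid in place of fluoro on that ring would leave the read-out within the scatter stays open. So does the effect of a longer chain in place of the ethenyl link.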